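Compound 4 in a cytotoxicity assay: an expected value

The source may hold more compounds than are shown below. What is called first, only, known or untested is meant among the compounds shown, and "the series" means these compounds.

Compound 1, `CC(C)Cc1ccc2c(NCCCNCc3ccco3)ccnc2c1`, gives 16000 nM in an ADME assay on HepG2 cells (Homo sapiens) for cytotoxicity, read by luminescence, CellTiter-Glo and ATP content, with a stated time of 72 h; on this read-out lower numbers stand for an effect already at smaller amounts and higher numbers for an effect only at larger amounts of compound.
Compound 2, `Clc1ccc(Oc2ccc3c(NCCCNCc4ccco4)ccnc3c2)cc1`, gives 7800 nM in this assay.
Compound 3, `COc1ccc(Oc2ccc3c(NCCCNCc4ccco4)ccnc3c2)cc1`, gives 5300 nM in this assay.

Of the three numbers, compound 3 holds the lowest, although the gap a 1.5-fold lower number from compound 2 to compound 3 (0.17 log units; within the scatter) lies within the scatter, so compound 2 and compound 3 cannot be told apart. The clearer movements are a 2.1-fold lower number from compound 1 to compound 2 (0.31 log units; beyond the scatter) and a 3.0-fold lower number from compound 1 to compound 3 (0.48 log units; beyond the scatter), both modest and both beyond the scatter, where an aryl ether took the place of isobutyl.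

Compound 4, `c1coc(CNCCCNc2ccnc3cc(-c4cccc5ccccc45)ccc23)c1`, differs from compound 3 in one place: naphthalen-1-yl in place of 4-methoxyphenoxy on an aromatic carbon. Among the measured compounds shown here, no measured pair shows an aromatic group attached directly to the shared core without an ether oxygen, so the two steps from compound 1 are the only guide, and they point to aromatic substituents giving somewhat lower numbers than an alkyl one. The swap of methoxy for chloro, a 1.5-fold lower number from compound 2 to compound 3 (0.17 log units; within the scatter), did not move the number beyond the scatter, suggesting that the nature of the distal aromatic part matters little here.

Compound 4 is therefore expected to give 4000 nM, within 1500 nM to 12000 nM, a step of a 1.3-fold lower number from compound 3 to compound 4 (0.12 log units; within the scatter) that is estimated to stay close to the scatter.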

Compound 4, half-maximal effective concentration: 5600 nM
The estimate for compound 4 lay 1.4-fold (0.15 log units) below the measured number; measured number inside the range.
By their numbers in this assay, from the lowest: compounds 3, 4 and 2 (each within the scatter of the next); then compound 1.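

In this assay, the ether oxygen proves not to be required at this position: naphthalen-1-yl, bonded directly to the aromatic carbon, gives a 1.1-fold higher number from compound 3 to compound 4 (0.02 log units; within the scatter) and a 1.4-fold lower number from compound 2 to compound 4 (0.14 log units; within the scatter), so compound 4 cannot be told apart from either aryl ether. The exchange removes both hydrogen-bond acceptors of 4-methoxyphenoxy and adds a second six-membered aromatic ring of carbon only, yet neither change shifts the number beyond the scatter. Set against isobutyl, the same group gives a 2.9-fold lower number from compound 1 to compound 4 (0.46 log units; beyond the scatter), so the modest separation from compound 1 now extends to a substituent without an ether link, though no data here account for any of these steps.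

What the compounds shown leave open is whether a plain phenyl ring joined directly to this carbon would sit at the same level as naphthalen-1-yl, and whether an amine, a carboxylic acid or a longer alkyl chain there would move the number at all. They also leave open whether this level holds once the side chain on the shared core is altered, since all four compounds carry the same one.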